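The source may hold more compounds than are shown below. What is called first, only, known or untested is meant among the compounds shown, and "the series" means these compounds.

Measured compounds:
Compound 1 `COc1ccc(Cc2cc(-c3cccs3)nn(CC(=O)Nc3ccc(Br)cc3)c2=O)cc1`. In an assay on HL-60 cells for agonist activity at N-formyl peptide receptor 3 (Homo sapiens), read by calcium flux (on this read-out higher numbers stand for an effect only at larger amounts of compound and lower numbers for an effect already at smaller amounts), compound 1 gives > 50000 nM, which is a limit of the assay and not a number.
Compound 2 `COc1cccc(Cc2cc(-c3cccs3)nn(CC(=O)Nc3ccc(F)cc3)c2=O)c1`. In this assay compound 2 gives > 50000 nM, again a limit.
Compound 3 `Cc1cc(Cc2cccc(F)c2)c(=O)n(CC(=O)Nc2ccc(Br)cc2)n1`. In this assay compound 3 gives > 50000 nM, also a limit.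

Compound 3 therefore stands where every value of the series stands: at the limit of > 50000 nM in this assay, at which 3 of the 3 values shown sit. For the measured compounds named here, since all three values are the same limit, no order among compounds 1, 2 and 3 can be drawn, and no step between measured compounds exists.

Compound 4 `Cc1cc(Cc2ccsc2)c(=O)n(CC(=O)Nc2ccc(Br)cc2)n1` differs from compound 3 in one place: thiophen-3-yl in place of 3-fluorophenyl on a saturated chain carbon bound to an aromatic carbon. Going by the values given here, no measured step covers this change. With every neighbour at the limit, no shift beyond the scatter in either direction is expected.

Compound 4 is therefore expected to give about 60000 nM in this assay, with a range of 20000 nM to 200000 nM, and most probably to be reported again only as a limit. The expected step is a step that the limit leaves unreadable from compound 3 to compound 4, none beyond the scatter.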

Compound 4, half-maximal effective concentration: > 50000 nM
Compound 4: only a limit was reported (the forecaster's own chance of this, stated with the estimate: 85%); the middle value lies beyond the limit too.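

No step can be read from compound 3 to compound 4, as both values are the same limit and not numbers: the limit of > 50000 nM in this assay, at which 4 of the 4 values shown sit.

The compounds shown leave open whether any change on the shared core gives a readable value, and how thiophen-3-yl and 3-fluorophenyl compare.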